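The compounds below may be only part of what the source reports. "The series", "measured", "known", "first", "only" and "open" are said of these compounds alone.

Measured compounds:
- compound 1, `Cc1ccc(OCC(=O)Nc2ccc(I)cc2C(N)=O)cc1`: 49.8%
- compound 2, `NC(=O)c1cc(I)ccc1NC(=O)COc1ccc(Cl)cc1Cl`: 74.7%
- compound 3, `Cc1ccc(OCC(=O)Nc2ccc(C)cc2C(N)=O)cc1`: 30.3%

All three were tested in a functional assay on K562 cells (Homo sapiens) for inhibition, read by trypan blue exclusion, with a stated time of 24 h, tested at 10 uM; a lower number here means less inhibition of growth, a higher number more inhibition of growth at the concentration tested. Compound 1 gives 49.8%, compound 2 gives 74.7%, and compound 3 gives 30.3%. Compound 3 is obtained from compound 1 by one change, (methyl in place of iodo on an aromatic carbon), and this change lowers the number: a number 19.5 percentage points lower from compound 1 to compound 3 (beyond the scatter). Compound 2 shares the amide and carbamoyl arrangement with compound 1 but carries a different aryl ether part; the difference between the two cores is not broken down here. Among the three measured compounds, compound 2 stands highest, with both of the others beyond the scatter below it.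

Compound 4, `Cc1ccc(NC(=O)COc2ccc(Cl)cc2Cl)c(C(N)=O)c1`, has not yet been measured. It is obtained from compound 2 by methyl in place of iodo on an aromatic carbon. This is the same change, at the same place, that turned compound 1 into compound 3. If the change behaves in the same way on the core of compound 2 as it did on the core of compound 1, the number should again fall by a modest amount, because a number 19.5 percentage points lower from compound 1 to compound 3 (beyond the scatter) was seen for that pair. Among the compounds with values here, with only one earlier example of the change, the expectation carries some uncertainty. For compound 4 in this assay the expected step is a number 19.7 percentage points lower from compound 2 to compound 4 (beyond the scatter). Compound 4 is therefore estimated at 55%, with a likely range from 40% to 68%.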

Compound 4, percent growth inhibition at one concentration: 35.4%
Estimate against measurement, compound 4: 19.6 percentage points above, outside the stated range (below it).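

In this assay, methyl in place of iodo on the core of compound 2 gives a number 39.3 percentage points lower from compound 2 to compound 4 (beyond the scatter), so the number falls on this core as it did on the core of compound 1. The direction of the change therefore carries over from one core to the other, but its size does not, and the two steps are set apart by more than the scatter expected for such a pair: the same change on two cores in this assay, a number 19.5 percentage points lower (beyond the scatter) from compound 1 to compound 3 and a number 39.3 percentage points lower (beyond the scatter) from compound 2 to compound 4, 19.8 percentage points apart, beyond the scatter of two such steps This shows that, in these two pairs, the size of the step depends on the core that carries it, so a step measured on one core is a poor guide to its exact size on another; it does not show why the size differs, and two pairs cannot tell how the change would behave on a third core.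

On these data alone, it remains open how a bromo, a chloro or an amine at this place would compare with iodo and methyl on either core. Also open, as far as these compounds go, is which part of the difference between the two aryl ether parts goes with the larger step, a question that a core carrying a single chloro on that part could help to answer.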